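A few compounds are considered here, and "the series" means these few. Any claim that something is new, unique, unknown or untested is made for them only; others in the source may bear on it.

Of the compounds shown here, three built on a shared core have been tested in an ADME assay on MIA PaCa-2 cells (Homo sapiens) for cytotoxicity, read by MTT assay, with a stated time of 72 h; on this read-out higher numbers stand for weaker inhibition and lower numbers for stronger inhibition. Compound 1 `COC(=O)c1cc(C2=C(c3cc(OC)c(OC)c(OC)c3)C(=O)CC2O[SiH2]C(C)(C)C)ccc1OC` gives > 100 ug/mL, which is a limit of the assay rather than a number. Compound 2 `COc1ccc(C2=C(c3cc(OC)c(OC)c(OC)c3)C(=O)CC2C)cc1C(=O)O` likewise gives > 100 ug/mL, again a limit. Compound 3 `COc1ccc(C2=C(c3cc(OC)c(OC)c(OC)c3)C(=O)C(O)C2)cc1NC(=O)c1ccccc1` gives > 100 ug/mL, also a limit. On these numbers compound 3 stands at the limit of > 100 ug/mL in this assay, at which 3 of the 3 values shown sit, and nothing separates it from the other two. Compound 4 `COc1ccc(C2=C(c3cc(OC)c(OC)c(OC)c3)C(=O)C(O)C2)cc1Cl` has not yet been measured in this assay. It differs from compound 3 in one place: chloro in place of benzamido on an aromatic carbon. Within the data shown here, no step between two measured compounds is available, so there is no measured change to lean on. As all three measured compounds sit at the limit of > 100 ug/mL in this assay, at which 3 of the 3 values shown sit, the expected step is a step that the limit leaves unreadable from compound 3 to compound 4, that is, none beyond the usual scatter. Compound 4 is therefore expected at 120 ug/mL in this assay, within 30 ug/mL to 400 ug/mL, with a real chance that the assay again reports only a limit.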

Compound 4, half-maximal inhibitory concentration: > 100 ug/mL
Compound 4: only a limit was reported; the forecaster's own chance of this, stated with the estimate: 70%; the middle value is on the limit's open side.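

No step can be read from compound 3 to compound 4, since each gives only a limit in this assay: the limit of > 100 ug/mL in this assay, at which 4 of the 4 values shown sit.

With no actual number among the compounds shown, it remains open how much chloro or benzamido on that aromatic carbon changes the inhibition.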